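Changing the group on the amine nitrogen, from compound 3 to compound 4

The source may hold more compounds than are shown below. What is called first, only, known or untested is meant among the compounds shown, and "the series" means these compounds.

Four compounds share one core and differ in the chain and in the group attached to an amine nitrogen. Compound 3 `C/N=C(\S)NCCCn1nc(-c2ccccc2)ccc1=O` is the starting point here. In a functional assay on the whole organism (stomach) with Rattus norvegicus as the target (a lower number here means that less compound is needed, a higher number that more compound is needed for the effect), compound 3 gives only a limit of the assay, > 100 mg/kg, and no number. Compound 2 `CC(C)C/N=C(\S)NCCCCn1nc(-c2ccccc2)ccc1=O` likewise gives only a limit in this assay, > 100 mg/kg. For the measured compounds named here, compound 1 `CC/N=C(/NC#N)NCCCCn1nc(-c2ccccc2)ccc1=O` is the single compound with a number in this assay, giving 92 mg/kg. Going by the values given here, the one measured step, an at least 1.0-fold higher number from compound 1 to compound 2 (0.03 log units; that floor lies within the scatter), is the same kind of change as the one considered now, taken in the opposite direction, and it rests on (the limit of > 100 mg/kg in this assay, at which 2 of the 3 values shown sit), so its true size stays open. Compound 4 `C/N=C(/NC#N)NCCCn1nc(-c2ccccc2)ccc1=O` carries, relative to compound 3, (a group of 6 heavy atoms (3 carbon, 3 nitrogen; no ring) in place of a group of 4 heavy atoms (2 carbon, 1 nitrogen, 1 sulfur; no ring), on an amine nitrogen). Guided by compound 1 with its 92 mg/kg, a move towards a number rather than a limit is expected, of uncertain size. Compound 4 is expected to give about 90 mg/kg, between 40 mg/kg and 200 mg/kg. The expected step is an at least 1.1-fold lower number from compound 3 to compound 4 (0.04 log units; that floor lies within the scatter).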

Compound 4, dose for half-maximal effect: > 100 mg/kg
Compound 4: no number, only a limit; the forecaster's own chance of this, stated with the estimate: 40%; at least 1.1-fold (0.04 log units) between middle value and limit.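

No new step can be read: compound 3 and compound 4 both give only a limit in this assay, so the change between them stays unreadable: the limit of > 100 mg/kg in this assay, at which 3 of the 4 values shown sit. The compounds shown leave open whether this change on the amine nitrogen alters the dose needed at all.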